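Swapping the methoxyphenyl ketone for a chlorophenyl ketone

A few compounds are considered here, and "the series" means these few. Any claim that something is new, unique, unknown or untested is made for them only; others in the source may bear on it.

Measured compounds and their values:
- compound 1 `COC(=O)c1cc(-c2cccc(NC(=O)c3ccc(/C=C/C(=O)c4cc(OC)c(OC)c(OC)c4)cc3)c2)on1`: in an ADME assay on Vero cells (Chlorocebus sabaeus) for cytotoxicity, read by MTT assay, with a stated time of 72 h (a higher number here means that more compound is tolerated, a lower number that less compound is tolerated), compound 1 gives > 50 ug/mL, a limit of the assay rather than a number.
- compound 2 `COC(=O)c1cc(-c2cccc(NC(=O)c3ccc(/C=C/C(=O)c4ccc(OC)cc4)cc3)c2)on1`: in this assay compound 2 gives > 10 ug/mL, again a limit, not a number.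

Among the compounds with values here, compound 2 therefore stands only at a limit, and the one further value shown, for compound 1, is a limit as well (the limit of > 10 ug/mL in this assay, at which 1 of the 2 values shown sits, (the limit of > 50 ug/mL in this assay, at which 1 of the 2 values shown sits)). Within the data shown here, the single step between them, a step that the two limits leave unreadable from compound 1 to compound 2, cannot be read in size or direction. Compound 3 `COC(=O)c1cc(-c2cccc(NC(=O)c3ccc(/C=C/C(=O)c4cccc(Cl)c4)cc3)c2)on1` differs from compound 2 in one place: 3-chlorophenyl in place of 4-methoxyphenyl on a carbonyl carbon. Among the measured compounds shown here, no measured step touches this change, and the only step recorded gives no number to lean on, so no step beyond the scatter is expected; the change from compound 2 to compound 3 is estimated as a step that the limit leaves unreadable from compound 2 to compound 3. Compound 3 is expected to sit near 30 ug/mL, within a range from 10 ug/mL to 100 ug/mL, most likely again reported as a limit.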

Compound 3, half-maximal cytotoxic concentration: > 2.5 ug/mL
Compound 3: no number, only a limit; the forecaster's own chance of this, stated with the estimate: 60%; the middle value does not contradict the limit.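

In this assay compound 3 gives > 2.5 ug/mL, a limit of the assay and not a number. Within the data shown here, compound 1, compound 2 and compound 3 all stand at limits, so no step among them can be read. As far as these compounds go, how much of each compound the cells tolerate remains open, as does whether these ketone aryl changes shift tolerance at all.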